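Nitro in place of acetyl: a small step expected

The compounds below may be only part of what the source reports. "The series", "measured", "known", "first", "only" and "open" are said of these compounds alone.

In a functional assay on A549 cells (Homo sapiens) for antiproliferative activity, read by MTT assay, with a stated time of 72 h (on this read-out lower numbers stand for stronger inhibition and higher numbers for weaker inhibition), compound 2 `CC(=O)c1ccc(N2CCN(C(=S)SCc3ccc4nc(N)nc(N)c4c3)CC2)cc1` gives 2550 nM and compound 1 `Nc1nc(N)c2cc(CSC(=S)N3CCN(c4ccccc4Cl)CC3)ccc2n1` gives 3610 nM in the same test, two values within the scatter of each other. Compound 3 `Nc1nc(N)c2cc(CSC(=S)N3CCN(c4ccc([N+](=O)[O-])cc4)CC3)ccc2n1`, not yet measured, has nitro in place of acetyl on an aromatic carbon and is otherwise the same as compound 2. Within the data shown here, only one measured step bears on this, a 1.4-fold lower number from compound 1 to compound 2 (0.15 log units; within the scatter) when the aromatic group on the ring nitrogen was exchanged, so no step beyond the scatter is expected. The estimated change is a 1.1-fold higher number from compound 2 to compound 3 (0.04 log units; within the scatter) with no clear direction. Compound 3 is estimated at 2800 nM with an expected range of 1200 nM to 6500 nM in this test.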

Compound 3, half-maximal inhibitory concentration: 1910 nM
Estimate against measurement, compound 3: 1.5-fold (0.17 log units) above, within the range that was stated.
By their numbers in this assay, from the lowest: compounds 3, 2 and 1 (each within the scatter of the next).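

At this ring carbon, para to a large group, nitro in place of acetyl gives a 1.3-fold lower number from compound 2 to compound 3 (0.13 log units; within the scatter) in this assay and so does not separate the two groups. Likewise, 4-nitrophenyl in place of 2-chlorophenyl on the ring nitrogen gives a 1.9-fold lower number from compound 1 to compound 3 (0.28 log units; within the scatter) and leaves these compounds unseparated too. No measurement is available that could explain these small steps. Going by these compounds, whether an amine or a carboxylic acid at this position would give a step beyond the scatter remains open.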